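Working notes: one group exchange on compound 3

The compounds below may be only part of what the source reports. "The series", "measured", "known", "first", "only" and "open" are said of these compounds alone.

Measured in a functional assay on CWR22R cells (Homo sapiens) for antiproliferative activity, read by propidium iodide staining, with a stated time of 96 h; a higher number here means a weaker inhibitor, a lower number a stronger inhibitor:
- compound 1 `CC(O)(CSc1cccc(S(F)(F)(F)(F)F)c1)C(=O)Nc1ccc(C#N)cc1C(F)(F)F`: 21600 nM
- compound 2 `CC(O)(CSc1ccc(S(F)(F)(F)(F)F)cc1)C(=O)Nc1cccc(S(F)(F)(F)(F)F)c1`: 13100 nM
- compound 3 `CC(O)(COc1cccc(S(F)(F)(F)(F)F)c1)C(=O)Nc1ccc(S(F)(F)(F)(F)F)cc1`: 17600 nM

In this assay, compound 3 gives 17600 nM, which lies within the scatter of the values of both other compounds. Compound 1 at 21600 nM and compound 2 at 13100 nM are also within the scatter of each other. For the measured compounds named here, these three compounds differ in more than one place, so no measured single-place step is available to guide the next comparison.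

Compound 4 `CC(O)(COc1cccc(OC(F)(F)F)c1)C(=O)Nc1ccc(S(F)(F)(F)(F)F)cc1` is compound 3 with one exchange: a group of 5 heavy atoms (1 carbon, 1 oxygen, 3 fluorine; no ring) in place of a group of 6 heavy atoms (5 fluorine, 1 sulfur; no ring), on an aromatic carbon. The trifluoromethoxy group enters on an aromatic carbon of a six-membered aromatic ring of carbon only, meta to a large group, and the rest of the structure is unchanged.

Going by the values given here, the only guide is the narrow spread of the three measured values, with compound 3 at 17600 nM as the direct reference. No shift beyond the scatter is therefore expected in this assay, and no direction is favoured. The expected change is a 1.1-fold higher number from compound 3 to compound 4 (0.03 log units; within the scatter), an estimate that stays within the scatter. For compound 4 the estimated value is 19000 nM, with an expected range of 9000 nM to 38000 nM.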

Compound 4, half-maximal inhibitory concentration: 17300 nM
Estimate against measurement, compound 4: 1.1-fold (0.04 log units) above; the range from low to high includes it.
By their numbers in this assay, from the lowest: compounds 2, 4, 3 and 1 (each within the scatter of the next).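

In this assay, for the compounds shown here, placing trifluoromethoxy on the aromatic carbon, meta to a large group, in place of the group of 6 heavy atoms (5 fluorine, 1 sulfur) gives a 1.0-fold lower number from compound 3 to compound 4 (0.01 log units; within the scatter), the only single-place step available. At this position, then, the two groups cannot be told apart in this read-out, even though the entering group carries one hydrogen-bond acceptor and the leaving group carries none. No measurement at hand offers an explanation for this result.

As far as these compounds go, the step covers a single exchange in a single setting, so it remains open whether the same exchange would leave the number unchanged with the sulfur link of compound 1 or compound 2 in place of the oxygen link of compound 3, or at another place on the ring. It is also open whether an amine or a carboxylic acid at this position would move the number beyond the scatter, as all four compounds shown lie within the scatter of their neighbours and no change that shifts activity in this assay has yet been seen.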